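Methylation of the ring amine and tolerated concentration

This account rests on a few compounds, and the source may have more. Where it says the series, first, only, none or still open, it means among the compounds named here.

Working notes on the series. In an ADME assay on MT2 cells (Homo sapiens) for cytotoxicity (a higher number here means that more compound is tolerated, a lower number that less compound is tolerated), compound 1 `CC(C)=CCOc1cc(Nc2ncnc(N)n2)ccc1Cl` gives 48000 nM. Compound 2 `CNc1ncnc(Nc2ccc(Cl)c(OCC=C(C)C)c2)n1` differs from compound 1 by methyl in place of hydrogen on a nitrogen on an aromatic ring, and in this assay compound 2 gives 3100 nM. The step recorded is a 15-fold lower number from compound 1 to compound 2 (1.19 log units; beyond the scatter), so less of compound 2 is tolerated than of compound 1.

Compound 3 `CC(C)=CCOc1cc(Nc2nccc(N)n2)ccc1C#N` is built on a different core; the difference between the two cores is not broken down here. In this assay compound 3 gives 41 nM, the lowest of the three numbers, with both compound 2 and compound 1 beyond the scatter above it.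

Compound 4 `CNc1ccnc(Nc2ccc(C#N)c(OCC=C(C)C)c2)n1` has not yet been measured. It differs from compound 3 by methyl in place of hydrogen on a nitrogen on an aromatic ring. The place of the change reads word for word as in the pair of compound 1 and compound 2, so this is the same change, seen twice in all among the compounds here. The expectation for the new pair rests on the earlier pair: because the earlier step was a 15-fold lower number from compound 1 to compound 2 (1.19 log units; beyond the scatter), a step in the same direction is expected from compound 3 to compound 4, estimated at a 6.8-fold lower number from compound 3 to compound 4 (0.83 log units; beyond the scatter), taken somewhat smaller since compound 3 already sits far lower in this assay than compound 1 did and the core is not the same. Compound 4 is therefore expected at about 6 nM in this assay. The expected range for compound 4 runs from 1.2 nM to 30 nM.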

Compound 4, half-maximal cytotoxic concentration: 22 nM
Estimate against measurement, compound 4: 3.7-fold (0.56 log units) below, and the stated range covers the measured number.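

In this assay, among these compounds, methyl in place of hydrogen on the nitrogen gives a 1.9-fold lower number from compound 3 to compound 4 (0.27 log units; within the scatter), so on the core of compound 3 the change produces no step that can be told from the scatter. Set beside the earlier step, the change does not carry over at the same size from one core to the other: the same change on two cores in this assay, a 15-fold lower number (1.19 log units; beyond the scatter) from compound 1 to compound 2 and a 1.9-fold lower number (0.27 log units; within the scatter) from compound 3 to compound 4, 8.3-fold (0.92 log units) apart, beyond the scatter of two such steps. This shows that, within these two pairs, the step read on one core is a poor guide to the size of the step on the other, but two pairs give no general rule for the series and do not show what sets the two steps apart.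

On these data alone, compound 1 and compound 3 differ in more than one place, with chlorine in one and nitrile in the other as well as different cores, so it remains open whether the gap between the steps goes with the core, with that other group, or with both together. Also open, as far as these compounds go, is how an ethyl group or a longer chain on the same nitrogen, in place of methyl, would read in this assay on either core.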